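Hydroxyethyl in Place of Cyclopentyl on the Amide

The source may report more compounds than this note shows. Statements on the series, on what has been measured and on what is new or still open speak of the compounds shown alone.

Measured compounds:
compound 1 `COc1cccc2cc(C(=O)NC3CCCC3)c(=N)oc12`: 20%
compound 2 `N=c1oc2ccc(Br)cc2cc1C(=O)NCCO`: 0%

In an assay on HeLa cells for displacement of a labelled ligand from adenosine receptor A3 (Homo sapiens), read by scintillation counting, with a stated time of 180 min, tested at 10 uM (on this read-out lower numbers stand for less inhibition and higher numbers for more inhibition at the one concentration tested (going by the name of the read-out)), compound 1 gives 20%, the higher of the two numbers, and compound 2 gives 0%, a gap beyond the usual scatter. Compound 3 `COc1cccc2cc(C(=O)NCCO)c(=N)oc12` differs from compound 1 in one place: 2-hydroxyethyl in place of cyclopentyl on an amide-type nitrogen. Compound 2 carries the same 2-hydroxyethyl group on its amide nitrogen and shows the lower value 0%, so a downward step is expected: a number 15 percentage points lower from compound 1 to compound 3 (beyond the scatter). Compound 3 is therefore estimated at 5%, most likely between 0% and 20%.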

Compound 3, a percentage reported as inhibition, at one concentration (the size of the read-out at that concentration, not a potency): 23%
Beside the measured number, compound 3's estimate is 18 percentage points below it; the measured number lies above the stated range.
By their numbers in this assay, from the lowest: compound 2; then compounds 1 and 3 (each within the scatter of the next).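

In this assay, 2-hydroxyethyl in place of cyclopentyl on the amide-type nitrogen reads as a number 3 percentage points higher from compound 1 to compound 3 (within the scatter) and so leaves the two groups indistinguishable on the core of compound 1. At this position, then, the carbon ring can give way to an open chain carrying a hydrogen-bond donor and acceptor with no measurable difference in this read-out. Nothing available explains this result. Going by these compounds, what remains open is how a longer chain, or an amine or carboxylic acid at the end of the chain, would read on this core.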